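The compounds below may be only part of what the source reports. "The series", "measured", "known", "first", "only" and "open" are said of these compounds alone.

Measured so far in this series:
compound 1 `CCCCCCCCC#Cc1cc2cn([C@@H]3O[C@H](CO)[C@@H](O)[C@@H]3O)c(=O)nc2o1` — a functional assay on HEL cells (Homo sapiens) for cytotoxicity; a higher number here means that more compound is tolerated, a lower number that less compound is tolerated: > 124000 nM, a limit of the assay
compound 2 `CCCCCCC#Cc1cc2cn([C@H]3C[C@H](O)[C@@H](CO)O3)c(=O)nc2o1` — this assay: 138000 nM
compound 3 `CCCCCCCCC#Cc1cc2cn(C)c(=O)nc2o1` — this assay: > 175000 nM, a limit of the assay

Compound 1 stands only at a limit in this assay, as the limit of > 124000 nM in this assay, at which 1 of the 3 values shown sits, records. Compound 3 also sits at a limit, as the limit of > 175000 nM in this assay, at which 1 of the 3 values shown sits, records. The step that the two limits leave unreadable from compound 1 to compound 3 therefore cannot be read. Compound 2 gives 138000 nM, a number, and of the three compounds it is the only one that does.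

Compound 4 `CCCCC#Cc1cc2cn([C@@H]3O[C@H](CO)[C@@H](O)[C@@H]3O)c(=O)nc2o1` is the next member. It differs from compound 1 in one place: hydrogen in place of butyl on a saturated chain carbon, four bonds along the chain from a triple-bonded carbon. For the measured compounds named here, no measured step bears directly on this shortening of the chain; the only measured step, from a nucleoside sugar to a methyl, is unreadable between its two limits. All three measured compounds sit at or near the top of the concentration range in this assay, with compound 2 giving a number close to both limits. On that basis no step beyond the scatter is expected for compound 4; the expected step that the limit leaves unreadable from compound 1 to compound 4 is essentially flat. Compound 4 is estimated at 150000 nM, with a range from 70000 nM to 400000 nM, and most likely the assay will again report only a limit.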

Compound 4, half-maximal cytotoxic concentration: > 144000 nM
Compound 4: no number, only a limit (the forecaster's own chance of this, stated with the estimate: 70%); the middle value does not contradict the limit.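

Compound 4 gives > 144000 nM, which is a limit of the assay. Compound 1 also stands only at a limit, so the step between compound 1 and compound 4 cannot be read. The compounds shown leave open whether shortening this chain changes the tolerated concentration in this assay at all.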